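The source may report more compounds than this note shows. Statements on the series, on what has been measured and on what is new or still open speak of the compounds shown alone.

Measured compounds so far:
Compound 1, `CC(C)CC1(Cc2ccccc2)OS(=O)(=O)C=C1OCc1ccccc1`: in an ADME assay on HEL cells (Homo sapiens) for cytotoxicity, with a stated time of 3 days (a higher number here means that more compound is tolerated, a lower number that less compound is tolerated), compound 1 gives >= 80000 nM.
Compound 2, `CCC1(Cc2ccccc2)OS(=O)(=O)C=C1OCc1ccc([N+](=O)[O-])cc1`: in this assay compound 2 gives >= 80000 nM.

The value of compound 1 in this assay is a limit of the assay, not a number. The value of compound 2 in this assay is likewise a limit of the assay and not a number. Among the compounds with values here, compound 2 therefore stands at the limit of >= 80000 nM in this assay, at which 2 of the 2 values shown sit, and since both measured compounds sit at that same limit, no step between measured compounds can be read off, and nothing is known here about how large a change in this read-out any structural change brings.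

Compound 3, `CCC1(Cc2ccccc2)OS(=O)(=O)C=C1OCc1ccc(C)cc1`, has not yet been measured in this assay. It differs from compound 2 as follows: methyl in place of nitro on an aromatic carbon. With both measured values only limits, the expected step of a number no higher from compound 2 to compound 3 (the limit leaves the size open) is none beyond the usual scatter. For compound 3 the estimated minimum cytotoxic concentration in this assay is 80000 nM, within a range from 40000 nM to 160000 nM, and it is expected that the assay most likely again reports only a limit rather than a number.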

Compound 3, minimum cytotoxic concentration: >= 16000 nM
Compound 3 was reported as a limit (the forecaster's own chance of this, stated with the estimate: 80%); the middle value is on the limit's open side.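

In this assay compound 3 gives >= 16000 nM, a limit of the assay and not a number. Compound 2 gives >= 80000 nM, likewise a limit. Within the data shown here, no step can therefore be read between compound 2 and compound 3. The compounds shown leave open what size of change in minimum cytotoxic concentration, if any, methyl in place of nitro brings.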